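Isopropyl Added to the Phenoxy Ring of a Sugar Scaffold

A few compounds are considered here, and "the series" means these few. Any claim that something is new, unique, unknown or untested is made for them only; others in the source may bear on it.

Compound 1 `CO[C@H]1O[C@H](COc2ccc(-c3ccccc3)cc2)[C@@H](O)[C@H](O)[C@H]1Oc1ccccc1` and compound 2 `CO[C@@H]1O[C@H](COc2ccc(-c3ccccc3)cc2)[C@@H](O)[C@H](O)[C@H]1Oc1ccccc1` share one core, and the only difference between them is the configuration as drawn (the fact that compounds 1 and 2 differ only in the configuration as drawn). In a functional assay on A549 cells (Homo sapiens) for cytotoxicity, read by MTT assay, with a stated time of 48 h (on this read-out higher numbers stand for an effect only at larger amounts of compound and lower numbers for an effect already at smaller amounts), compound 1 gives 36000 nM. For compound 2 in this assay no single number is available "not determined" (no result reported), so the only measured point of reference near compound 2 is compound 1, to which it is tied by the fact that compounds 1 and 2 differ only in the configuration as drawn.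

Compound 3 `CO[C@@H]1O[C@H](COc2ccc(-c3ccccc3)cc2)[C@@H](O)[C@H](O)[C@H]1Oc1cccc(C(C)C)c1` arises from compound 2 by isopropyl in place of hydrogen on an aromatic carbon, the isopropyl entering on a six-membered aromatic ring of carbon only, meta to a large group. Among the measured compounds shown here, no measured step shows what this addition does. The expectation for this assay is a step of moderate size, leaning toward an effect at smaller amounts of compound, but possibly no change beyond the usual scatter. Compound 3 is expected to give about 20000 nM in this assay, within a range from 5000 nM to 80000 nM.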

Compound 3, half-maximal effective concentration: 35000 nM
For compound 3 the middle estimate is 1.8-fold (0.24 log units) below the measured one; measured number inside the range.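

Among the compounds shown here, compound 2 has no single number in this assay, and compound 3 gives 35000 nM there, so no step from compound 2 to compound 3 can be read. The compounds shown leave open what the isopropyl group does to the effect in this series.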